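The source may hold more compounds than are shown below. What is called first, only, known or untested is meant among the compounds shown, and "the series" means these compounds.

Compound 1 `CCC[C@H](C)n1c(CC)nc2c(-c3ccc(OC(F)(F)F)cc3Cl)nccc21`: 2.3 nM
Compound 2 `CCCC(C)n1c(CC)nc2c(-c3ccc(Cl)cc3Cl)nccc21`: 3 nM
Compound 3 `CCCC(C)n1c(CC)nc2c(-c3ccc(OC(F)(F)F)cc3Cl)nccc21`: 2.8 nM

All three were tested in an assay for binding affinity to Corticotropin releasing factor receptor (Rattus norvegicus); on this read-out higher numbers stand for weaker inhibition and lower numbers for stronger inhibition. Compound 2 gives 3 nM, and its number lies within the scatter of both others: to compound 3 the step is a 1.1-fold lower number from compound 2 to compound 3 (0.03 log units; within the scatter), and the two values of compound 2 and compound 1 show no difference beyond the scatter. Compound 3 differs from compound 1 only in how one stereocentre is drawn, and the step of a 1.2-fold higher number from compound 1 to compound 3 (0.09 log units; within the scatter) is also within the scatter; that small gap fits (the fact that one of compounds 1 and 3 is drawn with a defined configuration and the other without, at the place where they differ).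

The new compound is compound 4 `CCCC(C)n1c(CC)nc2c(-c3ccc(Cl)cc3C)nccc21`. Its change from compound 2 is methyl in place of chloro on an aromatic carbon. Neither measured step touches this place: the step from compound 2 to compound 3 replaces a different chloro with trifluoromethoxy and stays within the scatter, and the other step is a stereo drawing only. Going by the values given here, with no step showing a change beyond the scatter, the step from compound 2 to compound 4 in this assay is expected to be a 1.3-fold higher number from compound 2 to compound 4 (0.12 log units; within the scatter), that is, small. Compound 4 is therefore estimated at 4 nM, with a range from 1.5 nM to 12 nM.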

Compound 4, inhibition constant: 9.1 nM
The estimate for compound 4 lay 2.3-fold (0.36 log units) below the measured number; the range from low to high includes it.
By their numbers in this assay, from the lowest: compounds 1, 3 and 2 (each within the scatter of the next); then compound 4.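

In this assay, going by these compounds alone, the swap from 2,4-dichlorophenyl to 4-chloro-2-methylphenyl gives a 3.0-fold higher number from compound 2 to compound 4 (0.48 log units; beyond the scatter) and so is the first single change here to go beyond the scatter. The earlier steps shown here, a stereo drawing and trifluoromethoxy at the other chloro, did not; this position, ortho to a large group, responds to the exchange of one heavy atom for another, with no change in hydrogen-bond donors, acceptors or net charge. Nothing given here bears on why this swap raises the number.

From the compounds shown here alone, whether a methoxy, a fluoro or an amine at this position would sit closer to compound 2 or to compound 4 remains open. Also open, going by these compounds, is whether the same swap would give a step of similar size in compound 3, which carries trifluoromethoxy at the other place.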